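From Chloro to Methyl on an Aromatic Carbon

The source may hold more compounds than are shown below. What is called first, only, known or untested is meant among the compounds shown, and "the series" means these compounds.

- compound 1 `Nc1ccccc1NC(=O)/C=C/c1ccc(CSc2ccc(Cl)cc2)cc1`: 59.6%
- compound 2 `COc1ccc(SCc2ccc(C(=O)Nc3ccccc3N)cc2)cc1`: 70.7%

In a functional assay on A549 cells (Homo sapiens) for inhibition, read by CCK-8 assay, with a stated time of 72 h, tested at 8 uM (on this read-out lower numbers stand for less inhibition of growth and higher numbers for more inhibition of growth at the one concentration tested), compound 1 gives 59.6% and compound 2 gives 70.7%. Compound 1 stands lowest of the two measured compounds, and the gap between the two lies beyond the scatter. Compound 3 `Cc1ccc(SCc2ccc(/C=C/C(=O)Nc3ccccc3N)cc2)cc1` has methyl in place of chloro on an aromatic carbon, para to a large group (methyl in place of chloro on an aromatic carbon). Going by the values given here, no two measured compounds differ in one place only, so the data offer no direct guide to this change. The expected result, a number 0.4 percentage points higher from compound 1 to compound 3 (within the scatter), is a step of no size beyond the scatter in this assay. For compound 3 the estimated value is 60%, with an expected range from 45% to 75%.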

Compound 3, percent growth inhibition at one concentration: 48.3%
For compound 3 the middle estimate is 11.7 percentage points above the measured one; the measured number falls inside the stated range.
By their numbers in this assay, from the lowest: compound 3; then compound 1; then compound 2.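

In this assay, going by these compounds alone, this gives the first comparison of compounds that differ in one place: methyl in place of chloro on an aromatic carbon, para to a large group, gives a number 11.3 percentage points lower from compound 1 to compound 3 (beyond the scatter). The position is therefore not indifferent to this exchange, and in this pair the 4-chlorophenyl compound is the more growth-inhibiting of the two. Nothing available explains the difference.

Going by these compounds, whether an amine, a carboxylic acid or a longer chain at this position would raise or lower the number stays open. So does whether the same exchange would act alike on another core.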